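Swapping chloro for fluoro on a pyrazole-linked phenyl

This account rests on a few compounds, and the source may have more. Where it says the series, first, only, none or still open, it means among the compounds named here.

Compound 1 `CC(C)(C)c1cc(CNC(=O)Nc2cccc3[nH]ncc23)n(-c2cccc(Cl)c2)n1`: 0.6 nM
Compound 2 `Cn1ncc2c(NC(=O)NCc3cc(C(F)(F)F)nn3-c3ccc(Cl)cc3)cccc21`: 2.7 nM
Compound 3 `Cn1ncc2c(NC(=O)NCc3cc(C(F)(F)F)nn3-c3ccc(F)cc3)cccc21`: 8.4 nM

All three were tested in an assay on CHO-K1 cells for antagonist activity at transient receptor potential cation channel subfamily V member 1 (Homo sapiens), read by FLIPR and calcium flux, with a stated time of 6 min; on this read-out lower numbers stand for stronger inhibition and higher numbers for weaker inhibition. Compound 1 gives the lowest number of the three, and compound 2 and compound 3 share one core while compound 1 has another; the difference between the two cores is not broken down here.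

Within the shared core of compound 2 and compound 3, one change is made: fluoro in place of chloro on an aromatic carbon. That change produced a 3.1-fold higher number from compound 2 to compound 3 (0.49 log units; beyond the scatter).

Compound 4 `CC(C)(C)c1cc(CNC(=O)Nc2cccc3[nH]ncc23)n(-c2cccc(F)c2)n1` has not yet been measured. It relates to compound 1 by fluoro in place of chloro on an aromatic carbon. This is the same kind of change as from compound 2 to compound 3, but the place differs: in compound 1 it is meta to a large group, while in compound 2 it is para to a large group.

Resting on the step from compound 2 to compound 3 a 3.1-fold higher number from compound 2 to compound 3 (0.49 log units; beyond the scatter) and the value of compound 1 0.6 nM, compound 4 is expected to show a 3.0-fold higher number from compound 1 to compound 4 (0.48 log units; beyond the scatter). Compound 4 is therefore estimated at 1.8 nM, with a likely range from 0.7 nM to 4.5 nM.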

Compound 4, inhibition constant: 1.3 nM
For compound 4 the middle estimate is 1.4-fold (0.14 log units) above the measured one, within the range that was stated.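

In this assay the swap of chloro for fluoro on the core of compound 1 gave a 2.2-fold higher number from compound 1 to compound 4 (0.34 log units; beyond the scatter), a move toward weaker inhibition, the same direction as on the core shared by compound 2 and compound 3. The sizes of the two steps can be set side by side, and they do not differ by more than repeated measurements would: the same change on two cores in this assay, a 3.1-fold higher number (0.49 log units; beyond the scatter) from compound 2 to compound 3 and a 2.2-fold higher number (0.34 log units; beyond the scatter) from compound 1 to compound 4, 1.4-fold (0.16 log units) apart, within the scatter of two such steps. So, in this small set, the change carried over from one core to the other with a similar effect even though it sits at a different place on the ring, but two pairs cannot show that it would hold on further cores, and they do not show why fluoro gives the higher number.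

The compounds shown carry only chloro or fluoro at this place, so what a methyl, a methoxy or a nitrile would do on the core of compound 1 remains open. Also open, going by these compounds, is how much each difference between the two cores contributes, since they differ in more than one place.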